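Urea series on the shared core: compound 2 to compound 3

The compounds below may be only part of what the source reports. "The series", "measured", "known", "first", "only" and "open" are said of these compounds alone.

Compound 2 `O=C(Nc1ccc(S(=O)(=O)Oc2ccccc2I)cc1)NC1CC1` gives 1300 nM in a functional assay on HT-1080 cells (Homo sapiens) for antiproliferative activity, read by sulforhodamine B assay, with a stated time of 48 h; a higher number here means a weaker inhibitor, a lower number a stronger inhibitor. Compound 1 `O=C(CCCl)Nc1ccc(S(=O)(=O)Oc2ccccc2I)cc1` gives 4200 nM in this assay. For the measured compounds named here, compound 2 therefore stands lowest of the two numbers measured so far; the single measured step, a 3.2-fold lower number from compound 1 to compound 2 (0.51 log units; beyond the scatter), separates it from the other compound.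

Compound 3 `O=C(NCC1CCCC1)Nc1ccc(S(=O)(=O)Oc2ccccc2I)cc1` differs from compound 2 in one place: cyclopentylmethyl in place of cyclopropyl on an amide-type nitrogen. Going by the values given here, the one step in hand concerns the carbonyl side, a change from 2-chloroethyl to cyclopropylamino, and so does not bear on an exchange of the ring substituent on the amide-type nitrogen. Among the compounds with values here, no measured step informs this change. With nothing to point either way, the expectation is a step that does not go beyond the scatter, in no firm direction, with wide uncertainty on both sides.

Compound 3 is accordingly estimated at 1300 nM in this assay, with a range from 400 nM to 4000 nM. This estimate corresponds to an expected step of no change at the digits printed from compound 2 to compound 3 (within the scatter).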

Compound 3, half-maximal inhibitory concentration: 6100 nM
Beside the measured number, compound 3's estimate is 4.7-fold (0.67 log units) below it; the measured number lies above the stated range.
By their numbers in this assay, from the lowest: compound 2; then compounds 1 and 3 (each within the scatter of the next).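

In this assay, for the compounds shown here, the substituent on the amide-type nitrogen proves to matter: a 4.7-fold higher number from compound 2 to compound 3 (0.67 log units; beyond the scatter), with cyclopentylmethyl in place of cyclopropyl, is the first measured change at this position and it lies beyond the scatter. The second reading, a 1.5-fold higher number from compound 1 to compound 3 (0.16 log units; within the scatter), shows that (cyclopentylmethyl)amino and 2-chloroethyl on the carbonyl carbon cannot be told apart here, so an amino group at that carbon does not by itself give the value of compound 2, 1300 nM; within these three compounds, it appears only with the cyclopropyl group. Nothing measured alongside these numbers accounts for the result, and it stands as an observation only.

Cyclopentylmethyl differs from cyclopropyl both in its ring, five-membered rather than three-membered, and in the carbon that sets that ring apart from the nitrogen, so these two differences remain unseparated; cyclopentyl or cyclopropylmethyl on the same nitrogen would divide them. Also open, from the compounds shown here alone, is how this nitrogen responds to an open-chain group such as isopropyl, or to a chain ending in an amine or a carboxylic acid.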